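Working notes: the step from compound 3 to compound 4

A few compounds are considered here, and "the series" means these few. Any claim that something is new, unique, unknown or untested is made for them only; others in the source may bear on it.

Compound 1 `COC(c1cc(Cl)c2c(c1Cl)C(=O)N(Cc1c(C)cc(C)[nH]c1=O)CC2)C1CCOC1` has several entries in an ADME assay on microsomes from liver (Homo sapiens) for metabolic stability, read by LC-MS, using NADPH, with stated times of 10 min and 45 min, tested at 1 uM; a lower number here means slower removal, a higher number faster removal of the compound: compound 1 gives 136 uL/min; 93.3 uL/min; 128 uL/min; 108 uL/min (4 entries), and the spread among these repeats the several entries of compound 1 in this assay, 136 uL/min; 93.3 uL/min; 128 uL/min; 108 uL/min (4 entries) shows how far single numbers in this assay can wander. Compound 2 `Cc1cc(C)c(CN2CCc3c(Cl)cc([C@H](CO)[C@H]4CCCO4)c(Cl)c3C2=O)c(=O)[nH]1` gives 51.6 uL/min in this assay, and compound 3 `Cc1cc(C)c(CN2CCc3c(Cl)cc([C@H](CO)[C@@H]4CCCO4)c(Cl)c3C2=O)c(=O)[nH]1` gives 37.6 uL/min. The step of a 1.4-fold lower number from compound 2 to compound 3 (0.14 log units; within the scatter) rests on a pair that differs in configuration alone (the fact that compounds 2 and 3 differ only in the configuration as drawn). Compound 3 therefore stands at 37.6 uL/min with compound 2 within the scatter of it, while the entries of compound 1 sit higher and give no single number.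

Compound 4 `Cc1cc(C)c(CN2CCc3c(Cl)cc([C@H](C)CO)c(Cl)c3C2=O)c(=O)[nH]1` differs from compound 3 at one place: a group of 4 heavy atoms (3 carbon, 1 oxygen; no ring) in place of a group of 8 heavy atoms (6 carbon, 2 oxygen; one five-membered non-aromatic ring with 1 hetero atom), on an aromatic carbon. Among the measured compounds shown here, no measured step touches this part of the structure; the only step in this assay, a 1.4-fold lower number from compound 2 to compound 3 (0.14 log units; within the scatter), changes configuration and stays within the scatter. The expectation for compound 4 therefore has no measured anchor beyond compound 3 itself, and the step of a 1.2-fold lower number from compound 3 to compound 4 (0.07 log units; within the scatter) is expected to stay within the scatter. Compound 4 is estimated at 32 uL/min in this assay, with a range from 15 uL/min to 70 uL/min.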

Compound 4, intrinsic clearance in a liver preparation (reported as CLH), per the amount of preparation that the assay uses: 15.8 uL/min
The estimate for compound 4 lay 2.0-fold (0.31 log units) above the measured number; low and high end bracket the measured number.
By their numbers in this assay, from the lowest: compound 4; then compounds 3 and 2 (each within the scatter of the next).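

Among the compounds shown here, the change at this aromatic carbon, 1-(hydroxymethyl)ethyl in place of the larger group with its five-membered non-aromatic ring, is the first in this assay to go beyond the scatter, with a 2.4-fold lower number from compound 3 to compound 4 (0.38 log units; beyond the scatter) and a 3.3-fold lower number from compound 2 to compound 4 (0.51 log units; beyond the scatter) pointing the same way. The lower number holds from either starting compound, so it does not depend on which of the two drawn configurations at the saturated ring carbon is the point of comparison: the fact that compounds 2 and 3 differ only in the configuration as drawn. Both steps are modest and rest on single entries, so their size calls for caution given how far repeated numbers can wander: the several entries of compound 1 in this assay, 136 uL/min; 93.3 uL/min; 128 uL/min; 108 uL/min (4 entries).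

The loss of the ring and the reduction in group size occur together in these compounds, and the compounds shown do not separate the two. Also open, from the compounds shown here alone, are how an amine, a carboxylic acid or a longer chain at this aromatic carbon would read in this assay, and whether the configuration of the stereocentre in 1-(hydroxymethyl)ethyl affects the number.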